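Benzyloxy for chloro on the aryl group of compound 2

The source may hold more compounds than are shown below. What is called first, only, known or untested is meant among the compounds shown, and "the series" means these compounds.

Compound 2 `Nc1nc(O)c2c(n1)n(C1OC(CO)[C@@H](O)[C@H]1O)c(=O)n2Cc1ccc(Cl)cc1` gives 14 uM in a functional assay (B cells) with Mus musculus as the target; on this read-out higher numbers stand for an effect only at larger amounts of compound and lower numbers for an effect already at smaller amounts. On the numbers shown it stands lowest of three, but its gap to compound 1 `CCn1c(=O)n(C2OC(CO)[C@@H](O)[C@H]2O)c2nc(N)nc(O)c21`, which gives 15 uM, is a 1.1-fold lower number from compound 1 to compound 2 (0.03 log units; within the scatter); only compound 3 `Nc1nc(O)c2c(n1)n(C1OC(CO)[C@@H](O)[C@H]1O)c(=O)n2CC(O)CO`, at 45 uM, sits clearly apart, since the step is a 3.2-fold higher number from compound 2 to compound 3 (0.51 log units; beyond the scatter). Against compound 1 the step to compound 3 is a 3.0-fold higher number from compound 1 to compound 3 (0.48 log units; beyond the scatter).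

Compound 4 `Nc1nc(O)c2c(n1)n(C1OC(CO)[C@@H](O)[C@H]1O)c(=O)n2Cc1ccc(OCc2ccccc2)cc1` differs from compound 2 by benzyloxy in place of chloro on an aromatic carbon. Going by the values given here, no measured step touches the aromatic carbon para to a large group; the known steps change what sits on the saturated chain carbon bound to an aromatic nitrogen, where methyl and 4-chlorophenyl gave like numbers and 1,2-dihydroxyethyl a modestly higher one. Among the compounds with values here, with no direct precedent, the expectation for compound 4 is a step of a 1.2-fold lower number from compound 2 to compound 4 (0.07 log units; within the scatter), within the scatter. Compound 4 is thus estimated at 12 uM in this assay, between 5 uM and 30 uM.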

Compound 4, concentration for half-maximal effect: 8 uM
Compound 4: middle estimate off by 1.5-fold (0.18 log units), on the high side; low and high end bracket the measured number.
By their numbers in this assay, from the lowest: compounds 4, 2 and 1 (each within the scatter of the next); then compound 3.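

Going by these compounds alone, the earlier compounds changed only what sits on the saturated chain carbon bound to an aromatic nitrogen, so this is the first reading at an aromatic carbon para to a large group. In this assay the change shows a 1.8-fold lower number from compound 2 to compound 4 (0.24 log units; within the scatter) and thus no separation from compound 2, even though 8 heavy atoms and one six-membered aromatic ring of carbon only enter where a single chlorine leaves. No evidence at hand accounts for this result.

Open, going by these compounds, is how an amine or a carboxylic acid on this aromatic carbon would read in this assay, since chloro and benzyloxy alone carry no hydrogen-bond donors and no net charge. Also open, on these data alone, is whether methoxy, or a longer chain ending in a phenyl ring, would stay within the scatter of compound 4.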